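Adding a Second Fluoro Group to Three Limit-Bound Compounds

A few compounds are considered here, and "the series" means these few. Any claim that something is new, unique, unknown or untested is made for them only; others in the source may bear on it.

Measured so far:
compound 1 `O=C(Nc1ccc2sc(-c3ccccc3)nc2c1)N1CCCCC1` gives > 50000 nM
compound 2 `O=C(Nc1ccc2sc(-c3cccc(F)c3)nc2c1)N1CCCC1` gives > 50000 nM
compound 3 `O=C(Nc1ccc2sc(-c3ccccc3F)nc2c1)N1CCCCC1` gives > 50000 nM

All three were tested in an ADME assay on HepG2 cells (Homo sapiens) for inhibition, read by resazurin assay, with a stated time of 48 h; on this read-out higher numbers stand for an effect only at larger amounts of compound and lower numbers for an effect already at smaller amounts. For compound 1 the value > 50000 nM is a limit of the assay, not a number. For compound 2 the value > 50000 nM is likewise a limit. For compound 3 the value > 50000 nM is a limit as well.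

Compound 1 and compound 3 differ by fluoro in place of hydrogen on an aromatic carbon. Going by the values given here, the step that the two limits leave unreadable from compound 1 to compound 3 stays unreadable because of the limit of > 50000 nM in this assay, at which 3 of the 3 values shown sit, where every value so far sits. The difference between the core of compound 1 and the core of compound 2 is not broken down here.

Compound 4 `O=C(Nc1ccc2sc(-c3cccc(F)c3F)nc2c1)N1CCCC1` has not been measured. It differs from compound 2 by fluoro in place of hydrogen on an aromatic carbon. This is the same kind of change as from compound 1 to compound 3, but the place is not identical: in compound 4 the entering fluoro group sits ortho to a fluoro group (1 heavy atom), whereas in compound 3 it sits only ortho to a large group.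

With nothing but the limit of > 50000 nM in this assay, at which 3 of the 3 values shown sit, to go on, the step of a number no higher from compound 2 to compound 4 (the limit leaves the size open) is expected to be small or again unreadable. In this assay compound 4 is estimated at 50000 nM, most likely reported once more as a limit.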

Compound 4, half-maximal effective concentration: > 50000 nM
Compound 4 was reported as a limit; the forecaster's own chance of this, stated with the estimate: 85%; the middle value lies on the limit itself.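

Compound 4 gives > 50000 nM, which is a limit of the assay and not a number. No size can be read for the step between compound 2 and compound 4, and the reason is this: the limit of > 50000 nM in this assay, at which 4 of the 4 values shown sit.

The compounds shown leave open whether fluoro in place of hydrogen changes the value in this assay at all, and how far any of compounds 1 to 4 lies from that limit.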